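A few compounds are considered here, and "the series" means these few. Any claim that something is new, unique, unknown or untested is made for them only; others in the source may bear on it.

Compound 1 `Cc1ncnc2c1c(I)cn2[C@@H]1O[C@H](CO)[C@@H](O)[C@H]1O`, compound 2 `CNc1ncnc2c1c(I)cn2[C@@H]1O[C@H](CO)[C@@H](O)[C@H]1O` and compound 3 `COc1ncnc2c1c(I)cn2[C@@H]1O[C@H](CO)[C@@H](O)[C@H]1O` are the three measured compounds. In a functional assay on K562 cells (Homo sapiens), read by MTT assay, with a stated time of 72 h (a lower number here means a stronger inhibitor, a higher number a weaker inhibitor), compound 1 gives 17800 nM. For compound 2 the assay reports only a limit, > 100000 nM. For compound 3 the assay likewise reports only a limit, > 20000 nM.

Compound 2 therefore stands at the top limit of the numbers shown (the limit of > 100000 nM in this assay, at which 1 of the 3 values shown sits); compound 3 sits at a lower limit (the limit of > 20000 nM in this assay, at which 1 of the 3 values shown sits), and compound 1 alone has a number. The step of an at least 5.6-fold higher number from compound 1 to compound 2 (0.74 log units; beyond the scatter) is the only one read as beyond the scatter; the step of an at least 1.1-fold higher number from compound 1 to compound 3 (0.05 log units; that floor lies within the scatter) stays within it, and the step that the two limits leave unreadable from compound 2 to compound 3 cannot be sized because both compounds are limits.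

Compound 4 `CNc1ncnc2c1c(-c1ccoc1)cn2[C@@H]1O[C@H](CO)[C@@H](O)[C@H]1O` differs from compound 2 at another position: furan-3-yl in place of iodo on an aromatic carbon. For the measured compounds named here, none of the measured steps touches this group; all three concern the substituent on the other aromatic carbon, so no measured step bears directly on the change. Compound 2 starts from a limit, so the expected step of an at least 2.0-fold lower number from compound 2 to compound 4 (0.30 log units; that floor lies within the scatter) is estimated from that limit alone, with wide uncertainty. Compound 4 is estimated at 50000 nM, within a range from 5000 nM to 200000 nM.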

Compound 4, half-maximal inhibitory concentration: > 20000 nM
Compound 4 ended at the assay's limit; the forecaster's own chance of this, stated with the estimate: 50%; the middle value is on the limit's open side.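

In this assay compound 4 gives only a limit, > 20000 nM, and compound 2 is also a limit, so the step between them cannot be read. The compounds shown leave open whether furan-3-yl in place of iodo changes the result in this assay at all, and by how much; neither compound has an exact number.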